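Removing both methyl groups from the N-phenyl ring

The source may hold more compounds than are shown below. What is called first, only, known or untested is meant among the compounds shown, and "the series" means these compounds.

Measured compounds:
compound 1 `Cc1cccc(-c2nc(CNc3ccc(C(=O)NO)cc3)n(-c3ccccc3)n2)c1` with 64.1%
compound 2 `Cc1ccc(-n2nc(-c3ccccc3)nc2CNc2ccc(C(=O)NO)cc2)cc1` with 60.7%
compound 3 `Cc1ccc(-n2nc(-c3ccccc3)nc2CNc2ccc(C(=O)NO)cc2)cc1C` with 53%

In an assay on Sf9 cells for inhibition of protein deacetylase HDAC6 (Homo sapiens), read by fluorescence, with a stated time of 40 min, tested at 100 nM (a lower number here means less inhibition, a higher number more inhibition at the concentration tested (going by the name of the read-out)), compound 3 gives 53%, the low end of the three numbers: compound 1 gives 64.1%, a number beyond the scatter above it, while compound 2 gives 60.7%, within the scatter of compound 3. The next compound, compound 4 `O=C(NO)c1ccc(NCc2nc(-c3ccccc3)nn2-c2ccccc2)cc1`, differs from compound 3 by phenyl in place of 3,4-dimethylphenyl on an aromatic nitrogen. Going by the values given here, only one measured step touches this position: a number 7.7 percentage points lower from compound 2 to compound 3 (within the scatter), a change that adds a single methyl on that ring and stays within the scatter. Among the compounds with values here, compound 4 takes off both methyls of compound 3, so the step runs the other way and somewhat further, but no measured pair shows the second methyl on its own. The expected outcome is therefore a small rise, likely within the scatter, given as a number 7 percentage points higher from compound 3 to compound 4 (within the scatter). Compound 4 is estimated at 60% in this assay, with a range from 48% to 72%.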

Compound 4, a percentage reported as inhibition, at one concentration (the size of the read-out at that concentration, not a potency): 72.6%
Compound 4: middle estimate off by 12.6 percentage points, on the low side, outside the stated range (above it).
By their numbers in this assay, from the lowest: compounds 3, 2, 1 and 4 (each within the scatter of the next, the first and the last beyond it).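

In this assay, going by these compounds alone, taking both methyl groups off the ring on the aromatic nitrogen gives a number 19.6 percentage points higher from compound 3 to compound 4 (beyond the scatter), so replacing 3,4-dimethylphenyl with phenyl has a clear effect, which the single-methyl step among the earlier compounds did not show. Removing only the remaining methyl from compound 2 gives a number 11.9 percentage points higher from compound 2 to compound 4 (beyond the scatter), while removing the methyl from the other phenyl ring of compound 1 gives a number 8.5 percentage points higher from compound 1 to compound 4 (within the scatter), a step within the scatter. A methyl added to an aromatic carbon has much the same size on these two different cores: the same change on two cores in this assay, a number 7.7 percentage points lower (within the scatter) from compound 2 to compound 3 and a number 8.5 percentage points lower (within the scatter) from compound 4 to compound 1, 0.8 percentage points apart, within the scatter of two such steps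

Among the compounds shown, these rings carry only hydrogen or methyl, so it remains open whether the higher number of compound 4 depends on having no substituent at all. A fluorine, a methoxy group or an amine on the phenyl ring could test this.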